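Fluorine position on the anilino ring: compound 3 to compound 4

This account rests on a few compounds, and the source may have more. Where it says the series, first, only, none or still open, it means among the compounds named here.

Measured in an in vitro assay on HEK-tsA201 cells for antagonist activity at Neuronal acetylcholine receptor; alpha3/beta4 (Homo sapiens), read by fluorescence and calcium flux; a higher number here means a weaker inhibitor, a lower number a stronger inhibitor:
compound 1 `CCCOc1ccc(C(=O)Nc2cccc(CC)n2)cc1`: 29200 nM
compound 2 `CCCCCNc1cccc(NC(=O)c2ccc(OCCC)cc2)n1`: only a limit of the assay, > 100000 nM
compound 3 `CCCOc1ccc(C(=O)Nc2cccc(Nc3cccc(F)c3)n2)cc1`: only a limit of the assay, > 100000 nM

Compound 3 sits at the limit of > 100000 nM in this assay, at which 2 of the 3 values shown sit, so its place among the three is known only as a limit. Starting from compound 1, the change of ethyl gave an at least 3.4-fold higher number from compound 1 to compound 3 (0.53 log units; beyond the scatter), and the parallel change gave an at least 3.4-fold higher number from compound 1 to compound 2 (0.53 log units; beyond the scatter). Between the two amino compounds, a step that the two limits leave unreadable from compound 2 to compound 3. Compound 4 `CCCOc1ccc(C(=O)Nc2cccc(Nc3ccc(F)cc3)n2)cc1` differs from compound 3 by 4-fluorophenyl in place of 3-fluorophenyl on a nitrogen on an aromatic ring. Among the compounds with values here, no measured step moves a fluorine around this ring, and compound 2 likewise gives only a limit. Compound 4 is therefore expected to stay at the limit in this assay, with a step that the limit leaves unreadable from compound 3 to compound 4 as the expected step. The estimate for compound 4 is 150000 nM, within 50000 nM to 500000 nM.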

Compound 4, half-maximal inhibitory concentration: > 100000 nM
Compound 4: only a limit was reported (the forecaster's own chance of this, stated with the estimate: 80%); the middle value is on the limit's open side.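

In this assay, replacing ethyl gave an at least 3.4-fold higher number from compound 1 to compound 4 (0.53 log units; beyond the scatter), so (4-fluorophenyl)amino joins pentylamino and (3-fluorophenyl)amino as a replacement with a weaker result than compound 1. The steps from compound 3 to compound 4 and from compound 2 to compound 4 cannot be read, so moving the fluorine shows no difference in either direction. Every amino compound here now rests at one limit: the limit of > 100000 nM in this assay, at which 3 of the 4 values shown sit.

Still open, from the compounds shown here alone, is how far the loss depends on the amino link, which a propyl or benzyl group in place of ethyl could test. Also open, going by these compounds, is whether a smaller group at this place, such as methylamino or a plain amine, gives a readable value.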